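The compounds below may be only part of what the source reports. "The series", "measured", "known", "first", "only" and "open" are said of these compounds alone.

Measured so far in a functional assay on MDA-MB-231 cells (Homo sapiens) for cytotoxicity, read by MTT assay, with a stated time of 72 h; a lower number here means a stronger inhibitor, a higher number a weaker inhibitor:
- compound 1 `O=C(CN1CCN(c2nnc(Cc3ccccc3)c3ccccc23)CC1)Nc1c(F)cccc1F`: 5490 nM
- compound 2 `O=C(CN1CCN(c2nnc(Cc3ccccc3)c3ccccc23)CC1)Nc1ccc(F)c(C(F)(F)F)c1`: 760 nM

Of these two, compound 2 holds the lower number, at 760 nM. Compound 3 `Cc1ccc(F)cc1NC(=O)CN1CCN(c2nnc(Cc3ccccc3)c3ccccc23)CC1` is the next to be read in this assay. It has 5-fluoro-2-methylphenyl in place of 4-fluoro-3-(trifluoromethyl)phenyl on an amide-type nitrogen.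

Among the measured compounds shown here, only one measured step bears on this change: a 7.2-fold lower number from compound 1 to compound 2 (0.86 log units; beyond the scatter), a modest step beyond the scatter that brought in the group compound 3 now gives up. For the measured compounds named here, no measured compound carries 5-fluoro-2-methylphenyl, so that single step sets only a rough scale. A partial return towards compound 1 at 5490 nM is expected, which means a modest step to a higher number, smaller than the measured one: a 2.5-fold higher number from compound 2 to compound 3 (0.40 log units; beyond the scatter) is the expected step. For compound 3 the estimated value is 1900 nM, with an expected range of 700 nM to 5500 nM.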

Compound 3, half-maximal inhibitory concentration: 19200 nM
Estimate against measurement, compound 3: 10-fold (1.00 log units) below; measured number above the stated range.
By their numbers in this assay, from the lowest: compound 2; then compound 1; then compound 3.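

In this assay, swapping the aryl group on the amide-type nitrogen can move the number further than the first pair indicated: the new step (a 25-fold higher number from compound 2 to compound 3 (1.40 log units; beyond the scatter)) is larger than the earlier one (a 7.2-fold lower number from compound 1 to compound 2 (0.86 log units; beyond the scatter)). 5-fluoro-2-methylphenyl does not fall between the two earlier groups, since the number also rises against the 2,6-difluorophenyl compound (a 3.5-fold higher number from compound 1 to compound 3 (0.54 log units; beyond the scatter)). All three aryl groups carry fluorine, so fluorine on the ring does not by itself fix the number in this set. Nothing at hand accounts for these differences.

With the methyl and trifluoromethyl groups changing together with the fluorine placement, the shown compounds cannot separate the contribution of each. As far as these compounds go, whether a chloro or nitrile group in place of trifluoromethyl would hold the number of compound 2 remains open.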